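The source may report more compounds than this note shows. Statements on the series, on what has been measured and on what is new or still open speak of the compounds shown alone.

Of the compounds shown here, two from this series have been tested in an ADME assay on MT4 cells (Homo sapiens) for cytotoxicity, with a stated time of 5 days; on this read-out lower numbers stand for higher toxicity in this test and higher numbers for lower toxicity in this test. Compound 1, `CC(C)(C)C#Cc1cc(N(C(=O)[C@H]2CC[C@H](C)CC2)[C@H]2CC[C@H](Oc3ccccn3)CC2)c(C(=O)O)s1`, reaches only the limit of the measurement and gives > 20000 nM. Compound 2, `C[C@H]1CC[C@H](C(=O)N(c2cc(C#CC3(C(F)(F)F)CCC3)sc2C(=O)O)[C@H]2CC[C@H](Oc3ccc(=O)[nH]n3)CC2)CC1`, likewise stops at the limit and gives > 20000 nM. Compound 2 thus stands at the limit of > 20000 nM in this assay, at which 2 of the 2 values shown sit, with no number beneath it to set it apart from compound 1. Compound 3, `CC(C)(C#Cc1cc(N(C(=O)[C@H]2CC[C@H](C)CC2)[C@H]2CC[C@H](Oc3ccc(=O)[nH]n3)CC2)c(C(=O)O)s1)C(F)(F)F`, has not yet been tested in this assay. It differs from compound 2 in one place: 1-methyl-1-(trifluoromethyl)ethyl in place of 1-(trifluoromethyl)cyclobutyl on a triple-bonded carbon. Within the data shown here, no measured step between two compounds exists here, so the size of such a change cannot be read from the data. Compound 2 sits at the limit of > 20000 nM in this assay, at which 2 of the 2 values shown sit. The step that the limit leaves unreadable from compound 2 to compound 3 is accordingly expected to be none beyond the usual scatter. Compound 3 is therefore expected to give 30000 nM, between 15000 nM and 80000 nM, most likely again reported only as a limit.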

Compound 3, half-maximal cytotoxic concentration: > 20000 nM
Compound 3 was reported as a limit; the forecaster's own chance of this, stated with the estimate: 85%; the middle value is on the limit's open side.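

Among these compounds, compound 2 and compound 3 both stop at a limit in this assay, so no step between them can be read: the limit of > 20000 nM in this assay, at which 3 of the 3 values shown sit. The compounds shown leave open where the true half-maximal cytotoxic concentration of each lies, and whether 1-methyl-1-(trifluoromethyl)ethyl in place of 1-(trifluoromethyl)cyclobutyl changes it at all.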